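The source may hold more compounds than are shown below. What is called first, only, known or untested is meant among the compounds shown, and "the series" means these compounds.

Compound 1, `CCCCn1ccc(N2CCC(c3ccccc3)CC2)c(C#N)c1=O`, gives 95 nM in a functional assay on CHO cells for positive allosteric modulation of metabotropic glutamate receptor 2 (Homo sapiens), with a stated time of 30 min; a lower number here means that less compound is needed, a higher number that more compound is needed for the effect.
Compound 2, `N#Cc1c(N2CCC(c3ccccc3)CC2)ccn(CC2CC2)c1=O`, gives 151 nM in this assay.
Compound 3, `N#Cc1c(N2CCC(c3ccccc3)CC2)ccn(CCC2CC2)c1=O`, gives 178 nM in this assay.

The three numbers lie close together. Compound 3 sits at the upper end of them, yet both a 1.9-fold higher number from compound 1 to compound 3 (0.27 log units; within the scatter) and a 1.2-fold higher number from compound 2 to compound 3 (0.07 log units; within the scatter) stay inside the usual scatter, as does a 1.6-fold higher number from compound 1 to compound 2 (0.20 log units; within the scatter). The chain on the aromatic nitrogen has so far been varied only among propyl, cyclopropylmethyl and 2-cyclopropylethyl, and none of these variations moved the read-out beyond what repeated measurement would give.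

Compound 4, `N#Cc1c(N2CCC(c3ccccc3)CC2)ccn(CCCC(F)(F)F)c1=O`, continues this series at the same place: 2,2,2-trifluoroethyl in place of cyclopropyl on a saturated chain carbon, two bonds along the chain from an aromatic nitrogen. The step that bears most directly on it is a 1.9-fold higher number from compound 1 to compound 3 (0.27 log units; within the scatter), which exchanged ethyl for cyclopropyl at exactly this carbon and stayed within the scatter; the two steps among compounds 1, 2 and 3 likewise stayed within it. Among the measured compounds shown here, no measured compound carries fluorine on this chain, so the data give no direction for the new group. The expectation is therefore a step of no more than the scatter in this assay, in either direction, which for compound 4 means a 1.1-fold higher number from compound 3 to compound 4 (0.05 log units; within the scatter). Compound 4 is thus estimated at 200 nM, with a range from 80 nM to 500 nM.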

Compound 4, half-maximal effective concentration: 355 nM
Beside the measured number, compound 4's estimate is 1.8-fold (0.25 log units) below it; the range from low to high includes it.
By their numbers in this assay, from the lowest: compounds 1, 2, 3 and 4 (each within the scatter of the next, the first and the last beyond it).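

Among the compounds shown here, the 4,4,4-trifluorobutyl chain is the first variation at this position to give a step beyond the scatter in this assay. For the compounds shown here, the clearest comparison is with compound 1, where trifluoromethyl in place of methyl, three bonds along the chain from an aromatic nitrogen, is the only change: the result is a 3.7-fold higher number from compound 1 to compound 4 (0.57 log units; beyond the scatter) and so the end of the chain is not indifferent to this exchange, even though the earlier variations at this position stayed within the scatter. The separation is only partial, since a 2.4-fold higher number from compound 2 to compound 4 (0.37 log units; beyond the scatter) also lies modestly beyond the scatter while a 2.0-fold higher number from compound 3 to compound 4 (0.30 log units; within the scatter) stays within it, leaving compound 4 set apart from the butyl and cyclopropylmethyl chains but not from the 2-cyclopropylethyl chain.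

Nothing shown here offers an explanation for the higher number with the fluorinated chain. On these data alone, it remains open whether a single fluorine at the chain end, a longer trifluoromethyl-capped chain, or a chain ending in a hydroxyl group or an amine would follow compound 4 or stay with compound 1.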